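Swapping nitro for amino on a diarylmethane core

A few compounds are considered here, and "the series" means these few. Any claim that something is new, unique, unknown or untested is made for them only; others in the source may bear on it.

Measured compounds and values:
compound 1 `COc1ccc(Cc2ccc(OC)c(OC)c2OC)cc1[N+](=O)[O-]` gives 2600 nM;
compound 2 `COc1ccc(Cc2cc(OC)c(OC)c(OC)c2)cc1[N+](=O)[O-]` gives 32 nM;
compound 3 `COc1ccc(C(=O)c2ccc3ccccc3c2)c(OC)c1OC` gives 3300 nM.

In a functional assay on HL-60 cells (Homo sapiens) for cytotoxicity, read by XTT assay, with a stated time of 72 h (a higher number here means a weaker inhibitor, a lower number a stronger inhibitor), compound 1 stands second highest of the three numbers. Its nearest neighbour is compound 3, whose number is slightly higher but within the scatter of repeat measurements, so no order between them can be claimed. Compound 2 stands far lower, well beyond the scatter. Compound 4 `COc1ccc(Cc2ccc(OC)c(OC)c2OC)cc1N` has not yet been measured. It differs from compound 1 in one place: amino in place of nitro on an aromatic carbon. Among the measured compounds shown here, no measured pair shows this change, so the size of the step is uncertain. Compound 4 is expected to land at 1500 nM, with a range from 300 nM to 6000 nM, a step of a 1.7-fold lower number from compound 1 to compound 4 (0.24 log units; within the scatter) that is estimated as a modest lowering.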

Compound 4, half-maximal inhibitory concentration: 230 nM
Compound 4: middle estimate off by 6.5-fold (0.81 log units), on the high side; measured number below the stated range.
By their numbers in this assay, from the lowest: compound 2; then compound 4; then compounds 1 and 3 (each within the scatter of the next).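

In this assay, the aromatic carbon ortho to a methoxy group proves sensitive to what it carries: amino in place of nitro gives an 11-fold lower number from compound 1 to compound 4 (1.05 log units; beyond the scatter), the only single change among these compounds. On this core, then, nitro is not needed at this position, and amino is the better of the two groups tested there. Nothing at hand accounts for the size of the step. As far as these compounds go, whether the same swap would lower the number on the core of compound 2 stays open. So does how a hydroxyl or an acetamide would fare on this carbon.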